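A few compounds are considered here, and "the series" means these few. Any claim that something is new, unique, unknown or untested is made for them only; others in the source may bear on it.

Measured so far in an ADME assay on TZM cells (Homo sapiens) for cytotoxicity, read by WST assay, with a stated time of 2 days; a higher number here means that more compound is tolerated, a lower number that less compound is tolerated:
compound 1 `Cc1c(Cc2c(Cl)cccc2Cl)nc(N(C)Cc2ccc(N3CCN(C)CC3)cc2)[nH]c1=O` gives 3200 nM
compound 2 `COc1ccc(CN(C)c2nc(Cc3c(Cl)cccc3Cl)c(C)c(=O)[nH]2)cc1` gives 17900 nM
compound 3 `Cc1c(C(C)c2c(F)cccc2F)nc(N(C)Cc2ccc(N3CCN(C)CC3)cc2)[nH]c1=O` gives 26200 nM

Compound 4 `COc1ccc(CN(C)c2nc(C(C)c3c(F)cccc3F)c(C)c(=O)[nH]2)cc1` is not yet measured. It differs from compound 3 by methoxy in place of 4-methylpiperazin-1-yl on an aromatic carbon. The same change, at the same place, separates compound 1 from compound 2 methoxy in place of 4-methylpiperazin-1-yl on an aromatic carbon and there made a 5.6-fold higher number from compound 1 to compound 2 (0.75 log units; beyond the scatter). The cores of compound 1 and compound 3 differ by 1-(2,6-difluorophenyl)ethyl in place of 2,6-dichlorobenzyl on an aromatic carbon, a change that made an 8.2-fold higher number from compound 1 to compound 3 (0.91 log units; beyond the scatter) in this assay. Compound 2 and compound 3 give numbers within the scatter of each other.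

From compound 3 to compound 4 the expected step in this assay is a 3.8-fold higher number from compound 3 to compound 4 (0.58 log units; beyond the scatter). For the measured compounds named here, this expectation rests on compound 1 and compound 2, whose step a 5.6-fold higher number from compound 1 to compound 2 (0.75 log units; beyond the scatter) is the only measured instance of the change; a single instance leaves the size uncertain, and a high starting number may leave less room. Compound 4 is therefore estimated at 100000 nM, between 40000 nM and 250000 nM.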

Compound 4, half-maximal cytotoxic concentration: 88800 nM
Estimate against measurement, compound 4: 1.1-fold (0.05 log units) above; the range from low to high includes it.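

In this assay, methoxy in place of 4-methylpiperazin-1-yl gives a 3.4-fold higher number from compound 3 to compound 4 (0.53 log units; beyond the scatter). The change carries from one core to the other in the same direction, and the two step sizes do not differ beyond the scatter: the same change on two cores in this assay, a 5.6-fold higher number (0.75 log units; beyond the scatter) from compound 1 to compound 2 and a 3.4-fold higher number (0.53 log units; beyond the scatter) from compound 3 to compound 4, 1.7-fold (0.22 log units) apart, within the scatter of two such steps

Two cores show that the step transfers within this pair of matched compounds, but they do not establish that it holds on other cores, and they do not explain why the number rises. Open, from the compounds shown here alone, is how other groups on the same aromatic carbon would behave, such as a morpholine, an open-chain amine or a carboxylic acid. Also open, going by these compounds, is whether the step survives when the 2,6-dichlorobenzyl or 1-(2,6-difluorophenyl)ethyl group gives way to an unsubstituted benzyl.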